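Cyclopentyl ether in place of propyl on an aminonaphthyridine

The compounds below may be only part of what the source reports. "The series", "measured", "known", "first", "only" and "open" are said of these compounds alone.

Compounds measured so far:
compound 1, `COCC(C)Oc1cccc2ccc(N)nc12`, 606 nM
compound 2, `CCCOc1cccc2ccc(N)nc12`, 1100 nM

In an assay on cells with melanin-concentrating hormone receptor 1 (Homo sapiens) as the target, read by radioligand binding (on this read-out lower numbers stand for stronger inhibition and higher numbers for weaker inhibition), compound 2 gives 1100 nM, the highest of the two numbers; the nearest is compound 1, and the step of a 1.8-fold higher number from compound 1 to compound 2 (0.26 log units; within the scatter) lies within the scatter. Compound 3, `CC1CCC(Oc2cccc3ccc(N)nc23)C1`, differs from compound 2 by 3-methylcyclopentyl in place of propyl on an oxygen on an aromatic ring. For the measured compounds named here, only the step from compound 1 to compound 2 bears on this change, and it was small, so no step beyond the scatter is expected. For compound 3 the estimate is 750 nM, between 250 nM and 2200 nM, a step of a 1.5-fold lower number from compound 2 to compound 3 (0.17 log units; within the scatter).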

Compound 3, half-maximal inhibitory concentration: 823 nM
Estimate against measurement, compound 3: 1.1-fold (0.04 log units) below, within the range that was stated.
By their numbers in this assay, from the lowest: compounds 1, 3 and 2 (each within the scatter of the next).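

Measured by this assay, the ether oxygen of the shared core carries a ring as well as an open chain, and two steps show no separation beyond the scatter (a 1.3-fold lower number from compound 2 to compound 3 (0.13 log units; within the scatter); a 1.4-fold higher number from compound 1 to compound 3 (0.13 log units; within the scatter)). The earlier pair compared only open chains, whereas 3-methylcyclopentyl brings a five-membered non-aromatic ring of carbon only to this place. Nothing available explains this flat result.

The compounds shown leave open whether a longer chain, a phenyl ring, an amine or a carboxylic acid on this oxygen would give a step beyond the scatter. They also leave open how changes elsewhere on the shared core would read.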